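Benzyl ring swap on the shared imidazole-biphenyl acid core

The source may hold more compounds than are shown below. What is called first, only, known or untested is meant among the compounds shown, and "the series" means these compounds.

Compound 1 `CC(C)(C)Cc1cnc(CCc2ccc(-c3ccccc3C(=O)O)cc2)[nH]1` and compound 2 `Cc1ccc(Cc2cnc(CCc3ccc(-c4ccccc4C(=O)O)cc3)[nH]2)cc1` share one core and differ only on a saturated chain carbon bound to an aromatic carbon. Going by the values given here, in an in vitro functional assay on cells for agonist activity at Bombesin receptor subtype-3 (Mus musculus), read by luminescence and calcium flux (a higher number here means that more compound is needed for the effect, a lower number that less compound is needed), compound 1 gives 6.3 nM, while compound 2 gives 162 nM, the highest of the two numbers measured so far; the step of a 26-fold higher number from compound 1 to compound 2 (1.41 log units; beyond the scatter) is large and beyond the scatter. Compound 3 `O=C(O)c1ccccc1-c1ccc(CCc2ncc(Cc3cccc(Cl)c3)[nH]2)cc1` is not yet measured. The change is 3-chlorophenyl in place of 4-methylphenyl on a saturated chain carbon bound to an aromatic carbon. Among the compounds with values here, no measured step exchanges one aromatic ring for another at this place; the only step known, a 26-fold higher number from compound 1 to compound 2 (1.41 log units; beyond the scatter), exchanges tert-butyl for 4-methylphenyl, so it does not bear directly on a ring-for-ring swap and gives only a sense of how sensitive this position can be. With nothing to point either way, the expectation for compound 3 in this assay is a step of a 1.4-fold lower number from compound 2 to compound 3 (0.13 log units; within the scatter) from compound 2, which lies within the usual scatter. Compound 3 is therefore estimated at 120 nM, in a range from 35 nM to 420 nM.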

Compound 3, half-maximal effective concentration: 31 nM
Beside the measured number, compound 3's estimate is 3.9-fold (0.59 log units) above it; measured number outside the range, below it.
By their numbers in this assay, from the lowest: compound 1; then compound 3; then compound 2.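

In this assay the step of a 5.2-fold lower number from compound 2 to compound 3 (0.72 log units; beyond the scatter) shows that this position responds to more than the presence of an aromatic ring: 4-methylphenyl and 3-chlorophenyl each bring 7 heavy atoms and one six-membered aromatic ring of carbon only, yet the number moves beyond the scatter. The loss seen on leaving tert-butyl therefore depends on which ring enters, since a 4.9-fold higher number from compound 1 to compound 3 (0.69 log units; beyond the scatter) is a smaller step than a 26-fold higher number from compound 1 to compound 2 (1.41 log units; beyond the scatter) and compound 1 still holds the lowest number of the three, with both of its steps beyond the scatter. Nothing at hand accounts for these differences between the groups.

The swap from compound 2 to compound 3 alters the ring substituent and its printed ring location together, so 3-methylphenyl and 4-chlorophenyl are the groups that would separate those two changes. Also open, going by these compounds, is whether a saturated ring such as cyclohexyl, or another branched alkyl chain, would keep the low number of compound 1 at this place on the shared core.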